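A few compounds are considered here, and "the series" means these few. Any claim that something is new, unique, unknown or untested is made for them only; others in the source may bear on it.

Measured so far in an assay on HEK293 cells for inhibition of Steryl-sulfatase (Homo sapiens), tested at 0.1 uM; on this read-out lower numbers stand for a weaker effect and higher numbers for a stronger effect at the one concentration tested:
compound 1 `CN(C)CCN(CCN(C)C)c1cccc(C(=O)N2CCc3ccc(OS(N)(=O)=O)cc3C2)c1` gives 0%
compound 2 `CN(CCCN1CCCCC1)c1ccc(C(=O)N2CCc3ccc(OS(N)(=O)=O)cc3C2)cc1` gives 17.4%
compound 3 `CCN(Cc1cccnc1)c1ccc(C(=O)N2CCc3ccc(OS(N)(=O)=O)cc3C2)cc1` gives 35.7%

Compound 2 stands second highest of the three numbers, beyond the scatter from compound 1 in this assay and beyond the scatter from compound 3. The shared core carries the sulfamate and the amide in all three; the compounds differ in the amino group on the aromatic carbon and in its position.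

Compound 4 `CCN(Cc1ccc(F)cc1)c1ccc(C(=O)N2CCc3ccc(OS(N)(=O)=O)cc3C2)cc1` is not yet measured. Against compound 2 the change is ethyl(4-fluorobenzyl)amino in place of methyl(3-(piperidin-1-yl)propyl)amino on an aromatic carbon on an aromatic carbon, para to a large group. Among the measured compounds shown here, one measured step bears on this: a number 18.3 percentage points higher from compound 2 to compound 3 (beyond the scatter), where a methyl(3-(piperidin-1-yl)propyl)amino group was likewise exchanged for an ethyl-bearing amino group carrying a six-membered aromatic ring. Compound 4 carries the same ethyl group and a six-membered aromatic ring of carbon only instead of the pyridin-3-yl ring, so a step of similar size and direction is expected in this assay, beyond the scatter. For compound 4 the expected value in this assay is 32%, in the range 15% to 50%, a step of a number 14.6 percentage points higher from compound 2 to compound 4 (beyond the scatter) expected from compound 2. For the measured compounds named here, no second example of this kind of exchange exists among the three measured compounds, so the range is kept wide.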

Compound 4, a percentage reported as inhibition, at one concentration (the size of the read-out at that concentration, not a potency): 69.1%
For compound 4 the middle estimate is 37.1 percentage points below the measured one; measured number outside the range, above it.
By their numbers in this assay, from the lowest: compound 1; then compound 2; then compound 3; then compound 4.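

In this assay, the amino group on this aromatic carbon, para to a large group, has a much stronger effect on the read-out than compounds 1 to 3 indicated, with a number 51.7 percentage points higher from compound 2 to compound 4 (beyond the scatter) for the exchange of the whole group. The aromatic ring at the end of that group also matters: with the ethyl group and the amino nitrogen unchanged, 4-fluorophenyl in place of pyridin-3-yl gives a number 33.4 percentage points higher from compound 3 to compound 4 (beyond the scatter). No measurement on hand explains either step.

The step from compound 3 to compound 4 changes both the ring nitrogen and the fluorine, so the two contributions remain unseparated; a plain phenyl group on the same chain carbon would separate them. Going by these compounds, whether a 4-chlorophenyl or 4-methoxyphenyl group would give a similar read-out also remains open.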